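Trading a Chloro Group for Hydrogen on Compound 1

The source may hold more compounds than are shown below. What is called first, only, known or untested is meant among the compounds shown, and "the series" means these compounds.

Compound 1 `Nc1ccccc1NC(=O)c1ccc(NC(=S)NCc2ccc(Cl)nc2)cc1` is tested in a functional assay on HepG2 cells (Homo sapiens) for cytotoxicity, read by MTT assay, with a stated time of 72 h (a lower number here means a stronger inhibitor, a higher number a weaker inhibitor), and compound 1 gives 19000 nM. Among the measured compounds shown here, that is the higher of the two numbers measured so far. The other tested molecule, compound 2 `Nc1ccccc1NC(=O)c1ccc(CNC(=O)c2cc3cnccc3[nH]2)cc1`, gives 1700 nM, a gap beyond the usual scatter, so compound 1 is the weaker inhibitor of the pair. Compound 3 `Nc1ccccc1NC(=O)c1ccc(NC(=S)NCc2cccnc2)cc1` is not yet measured. It differs from compound 1 in a single place, with hydrogen in place of chloro on an aromatic carbon, so that 6-chloropyridin-3-yl becomes pyridin-3-yl. For the measured compounds named here, no measured pair shows this change on its own, so the forecast stays cautious. The expected change is small, a 1.3-fold lower number from compound 1 to compound 3 (0.10 log units; within the scatter), slightly toward a lower number and within the scatter. For compound 3 the estimated value in this assay is 15000 nM, with an expected range of 5000 nM to 45000 nM.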

Compound 3, half-maximal inhibitory concentration: 4200 nM
Compound 3: middle estimate off by 3.6-fold (0.55 log units), on the high side; measured number outside the range, below it.
By their numbers in this assay, from the lowest: compound 2; then compound 3; then compound 1.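

Going from 6-chloropyridin-3-yl to pyridin-3-yl gives a 4.5-fold lower number from compound 1 to compound 3 (0.66 log units; beyond the scatter) in this assay, so a change of a single atom on this aromatic carbon, next to the ring nitrogen, moves the number beyond the usual scatter. This is the only one-place comparison shown, and it indicates that the chloro group is not needed for activity here, since the compound without it is the stronger inhibitor of the pair. Among the compounds shown here, nothing measured so far explains this shift.

A single step cannot say whether hydrogen is especially favourable at this carbon or chloro merely unfavourable; a fluoro group, a methyl group or an amine in the same place would help separate the two. Going by these compounds, it also remains open whether the step would hold in a different cell line.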